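Acylating the Amino Group of Compound 3

The compounds below may be only part of what the source reports. "The series", "measured", "known", "first", "only" and "open" are said of these compounds alone.

Measured so far:
Compound 1 `Cc1cc(Cc2cccs2)c(=O)n(CC(=O)Nc2ccc(Br)cc2)n1`, in an assay on HL-60 cells for agonist activity at N-formyl peptide receptor 3 (Homo sapiens), read by calcium flux (on this read-out higher numbers stand for an effect only at larger amounts of compound and lower numbers for an effect already at smaller amounts), compound 1 gives 10200 nM.
Compound 2 `Cc1cc(Cc2cccnc2)c(=O)n(CC(=O)Nc2ccc(Br)cc2)n1`. In this assay compound 2 reaches only the limit > 50000 nM.
Compound 3 `Cc1cc(N)c(=O)n(CC(=O)Nc2ccc(Br)cc2)n1`. In this assay compound 3 likewise reaches only the limit > 50000 nM.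

Compound 3 thus stands at the limit of the assay, which is where two of the three values sit (the limit of > 50000 nM in this assay, at which 2 of the 3 values shown sit). Compound 4 `COc1cccc(C(=O)Nc2cc(C)nn(CC(=O)Nc3ccc(Br)cc3)c2=O)c1` differs from compound 3 by (3-methoxyphenyl)carbonyl in place of hydrogen on a nitrogen on an aromatic ring. Among the measured compounds shown here, none of the measured steps changes this nitrogen; the nearest is the exchange of a (thiophen-2-yl)methyl group for amino on the same ring carbon, which gave an at least 4.9-fold higher number from compound 1 to compound 3 (0.69 log units; beyond the scatter), and the step that the two limits leave unreadable from compound 2 to compound 3. Since compound 3 is known only as a limit, the size of the step to compound 4 cannot be read from the data, but restoring a larger aromatic group at this position is expected to bring the value back from the limit, giving an estimated at least 16-fold lower number from compound 3 to compound 4 (1.22 log units; beyond the scatter). For compound 4 the expected value is 3000 nM, within 500 nM to 30000 nM.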

Compound 4, half-maximal effective concentration: > 50000 nM
Compound 4 was reported as a limit; the forecaster's own chance of this, stated with the estimate: 25%; middle value at least 16-fold (1.22 log units) from the limit.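

Compound 4 gives > 50000 nM, which is a limit of the assay. Compound 3 is also known only as a limit, so no step can be read between compound 3 and compound 4. The compounds shown leave open how far (3-methoxyphenyl)carbonyl on this nitrogen changes the value, as most values remain at one limit: the limit of > 50000 nM in this assay, at which 3 of the 4 values shown sit.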